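The source may hold more compounds than are shown below. What is called first, only, known or untested is meant among the compounds shown, and "the series" means these compounds.

Compound 1 `Cc1oc2c3c(ccc2c(=O)c1C)OC[C@H]1[C@@H]3C2=C(CCCC2=O)OC1(C)C` gives > 100000 nM in a functional assay on A549 cells (Homo sapiens) for antiproliferative activity, read by MTT assay, with a stated time of 48 h (on this read-out higher numbers stand for weaker inhibition and lower numbers for stronger inhibition), which is a limit of the assay and not a number.
Compound 2 `Cc1oc2c3c(ccc2c(=O)c1-c1ccccc1)OC[C@H]1[C@@H]3C2=C(CC(C)(C)CC2=O)OC1(C)C` gives > 100000 nM in this assay, again a limit.
Compound 3 `Cc1nn(-c2ccccc2)c2c1[C@@H]1c3c(ccc4c(=O)c(C)c(C)oc34)OC[C@@H]1C(C)(C)O2` gives > 100000 nM in this assay, once more a limit.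

Compound 3 therefore stands nowhere in particular on the numbers shown: its own result is only a limit, and the same is true of the two other compounds, since all three sit at the limit of > 100000 nM in this assay, at which 3 of the 3 values shown sit. For the measured compounds named here, no step between measured compounds that differ in one place is available, so nothing measured tells how any single change moves the read-out.

Compound 4 `Cc1nn(-c2ccccc2)c2c1[C@@H]1c3c(ccc4c(=O)c(-c5ccccc5)c(C)oc34)OC[C@@H]1C(C)(C)O2` is related to compound 3 by one change, (phenyl in place of methyl on an aromatic carbon). Compound 2 already carries a phenyl at a comparable position and also gives only a limit. On that basis the expectation for compound 4 is no step beyond the usual scatter, with a number no higher from compound 3 to compound 4 (the limit leaves the size open) expected to be negligible. Compound 4 is estimated at 100000 nM in this assay, with a range from 30000 nM to 300000 nM, and most likely reported again only as a limit.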

Compound 4, half-maximal inhibitory concentration: > 100000 nM
Compound 4: a limit, no number (the forecaster's own chance of this, stated with the estimate: 85%); the middle value sits exactly at the limit.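

No step can be read from compound 3 to compound 4, because both results are limits of the assay and not numbers: the limit of > 100000 nM in this assay, at which 4 of the 4 values shown sit. The compounds shown leave open how phenyl in place of methyl, or any other single change, moves the read-out in this assay for this series.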